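The source may report more compounds than this note shows. Statements on the series, on what has been measured and on what is new or still open speak of the compounds shown alone.

Measured compounds:
compound 1, `Cc1cccc(/C(N)=N/NC(=S)N2CCSCC2)n1`, 60.1%
compound 2, `Cc1ccnc(/C(N)=N/NC(=S)N2CCSCC2)c1`, 67.2%

The two compounds share one core and differ only in where the methyl sits on the ring. In a functional assay on A-375 cells (Homo sapiens) for cytotoxicity, read by MTT assay, with a stated time of 72 h, tested at 3 uM (a lower number here means less inhibition of growth, a higher number more inhibition of growth at the concentration tested), compound 1 gives 60.1%, and compound 2 gives 67.2%; the two values lie within the usual scatter of each other, so compound 2 stands level with compound 1 rather than apart from it. Compound 3, `N/C(=N\NC(=S)N1CCSCC1)c1ccccn1`, has not yet been measured. Relative to compound 2 it carries hydrogen in place of methyl on an aromatic carbon, hydrogen in place of methyl on an aromatic carbon. Within the data shown here, no step between measured compounds is available as a guide, and the two numbers that exist sit close together, so the expected step of a number 5.2 percentage points lower from compound 2 to compound 3 (within the scatter) is small, in no clear direction, and not beyond the scatter. Compound 3 is therefore expected to give 62%, with a range from 48% to 76%.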

Compound 3, percent growth inhibition at one concentration: 80%
Beside the measured number, compound 3's estimate is 18 percentage points below it, and the stated range ends below it.
By their numbers in this assay, from the lowest: compounds 1 and 2 (each within the scatter of the next); then compound 3.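

In this assay, hydrogen in place of methyl on an aromatic carbon gives a number 12.8 percentage points higher from compound 2 to compound 3 (beyond the scatter) and a number 19.9 percentage points higher from compound 1 to compound 3 (beyond the scatter) and so separates the compounds, as the two methyl placements alone had not. For compound 2, the methyl left from the carbon opposite the ring nitrogen, so a methyl there is not needed for growth inhibition at the concentration tested. No measurement shown accounts for this gain.

The compounds shown leave open whether any other group at this position, such as a chlorine atom, an amine or an ethyl group, would match hydrogen. They also leave open how compound 3 would compare across a range of concentrations.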